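Removing a methylamino group from a fused thiosemicarbazone core

The source may hold more compounds than are shown below. What is called first, only, known or untested is meant among the compounds shown, and "the series" means these compounds.

Measured in a functional assay on MIA PaCa-2 cells (Homo sapiens) for cytotoxicity, read by luminescence, with a stated time of 72 h; a lower number here means a stronger inhibitor, a higher number a weaker inhibitor:
compound 1 `CNc1c(F)ccc2c(C=NNC(=S)N(C)C)nccc12`: 272 nM
compound 2 `CN(C)C(=S)NN=Cc1nccc2cc(F)ccc12`: 111 nM
compound 3 `CNc1cccc2c(C=NNC(=S)N(C)C)ncc(F)c12`: 327 nM

Compound 1 and compound 2 differ by hydrogen in place of methylamino on an aromatic carbon, and the step was a 2.5-fold lower number from compound 1 to compound 2 (0.39 log units; beyond the scatter). Compound 3 has the same atoms as compound 1 joined differently; how the two cores differ is not broken down here, and in this assay compound 3 gives 327 nM, within the scatter of compound 1. Compound 4 `CN(C)C(=S)NN=Cc1ncc(F)c2ccccc12`, not yet measured, differs from compound 3 by hydrogen in place of methylamino on an aromatic carbon. This is the same kind of change as from compound 1 to compound 2, but the place differs: there the aromatic carbon was ortho to a fluoro group, here it is not. Resting on the step from compound 1 to compound 2 and on compound 3 giving 327 nM, the account expects in this assay a step of a 2.3-fold lower number from compound 3 to compound 4 (0.37 log units; beyond the scatter). Compound 4 is thus estimated at 140 nM, between 60 nM and 330 nM.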

Compound 4, concentration for 90% inhibition: 274 nM
Estimate against measurement, compound 4: 2.0-fold (0.29 log units) below; the range from low to high includes it.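

In this assay, hydrogen in place of methylamino on the core of compound 3 gives a 1.2-fold lower number from compound 3 to compound 4 (0.08 log units; within the scatter), so this pair cannot be told apart. Set beside the earlier step, the change does not separate the two cores: the same change on two cores in this assay, a 2.5-fold lower number (0.39 log units; beyond the scatter) from compound 1 to compound 2 and a 1.2-fold lower number (0.08 log units; within the scatter) from compound 3 to compound 4, 2.1-fold (0.31 log units) apart, within the scatter of two such steps. The two steps are therefore compatible with one shared effect, yet two pairs in one assay do not show that it carries to any further core, and they cannot settle whether the change truly counts for more on the core of compound 1.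

The compounds shown leave open how a different group on that aromatic carbon, such as a dimethylamino group or an amine with a longer chain, would compare. They also leave open whether these pairs would read the same way in other cells.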